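Side-chain change from compound 1 to compound 4

A few compounds are considered here, and "the series" means these few. Any claim that something is new, unique, unknown or untested is made for them only; others in the source may bear on it.

Compound 1 (`NCCCNc1c(C(=O)NCc2ccc(F)cc2)nc(Br)c2cccnc12`) has no number to stand on: in a functional assay on SK-BR-3 cells (Homo sapiens) for cytotoxicity, read by MTT assay, with a stated time of 72 h (a higher number here means a weaker inhibitor, a lower number a stronger inhibitor), compound 1 reads "not determined" (no result reported). Two relatives give the only reference points. Compound 2 (`CC(C)(C)OC(=O)N1CCN(c2c(C(=O)NCc3ccc(F)cc3)nc(Br)c3cccnc23)CC1`) gives 3000 nM and compound 3 (`N[C@H]1CC[C@H](Nc2c(C(=O)NCc3ccc(Cl)cc3)nc(Br)c3cccnc23)CC1`) gives 2000 nM, values within the scatter of each other. Compound 4 (`COC(=O)CNc1c(C(=O)NCc2ccc(F)cc2)nc(Br)c2cccnc12`) carries the change (methoxycarbonyl in place of 2-aminoethyl on a saturated chain carbon bound to a nitrogen on an aromatic ring), that is, methoxycarbonyl in place of 2-aminoethyl on a saturated chain carbon bound to a nitrogen on an aromatic ring. Going by the values given here, no step from compound 1 can be read, so the expectation in this assay rests on compound 2 at 3000 nM and is for no step beyond the scatter, in either direction. Compound 4 is expected at 3000 nM, with an estimated range of 1000 nM to 9000 nM.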

Compound 4, half-maximal inhibitory concentration: 1000 nM
The estimate for compound 4 lay 3.0-fold (0.48 log units) above the measured number, and the stated range covers the measured number.
By their numbers in this assay, from the lowest: compounds 4, 3 and 2 (each within the scatter of the next, the first and the last beyond it).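

Going by these compounds alone, no step from compound 1 to compound 4 can be read in this assay. The compounds shown leave open how methoxycarbonyl and 2-aminoethyl compare on the shared core. No supporting data bear on the value of compound 4.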